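Aryl ether variations on the shared core: outlook for compound 4

The compounds below may be only part of what the source reports. "The series", "measured", "known", "first", "only" and "open" are said of these compounds alone.

In an assay on V79MZh11B2 cells for inhibition of cytochrome P450 11B2, mitochondrial (Homo sapiens), read by HPLC, with a stated time of 25 min (a higher number here means a weaker inhibitor, a lower number a stronger inhibitor), the three measured compounds give the following:
compound 1 `O=c1cc(Cn2ccnc2)c2ccc(OCc3cc(F)cc(F)c3)cc2o1`: 200 nM
compound 2 `COc1ccc(COc2ccc3c(Cn4ccnc4)cc(=O)oc3c2)cc1`: 124 nM
compound 3 `COc1cccc(COc2ccc3c(Cn4ccnc4)cc(=O)oc3c2)c1`: 127 nM

Compound 3 sits second highest of the three numbers. Its nearest neighbour is compound 2, with a 1.0-fold higher number from compound 2 to compound 3 (0.01 log units; within the scatter) separating them; the furthest is compound 1, with a 1.6-fold lower number from compound 1 to compound 3 (0.20 log units; within the scatter). Neither gap exceeds the scatter, so the three measured compounds are not distinguishable on these numbers.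

Compound 4 `O=c1cc(Cn2ccnc2)c2ccc(OCc3cccc(F)c3)cc2o1` differs from compound 3 by fluoro in place of methoxy on an aromatic carbon. Among the compounds with values here, the steps that bear on it are those that already vary the aromatic substituent on the same benzylic position: a 1.6-fold lower number from compound 1 to compound 2 (0.21 log units; within the scatter), a 1.6-fold lower number from compound 1 to compound 3 (0.20 log units; within the scatter) and a 1.0-fold higher number from compound 2 to compound 3 (0.01 log units; within the scatter). All three are within the scatter, including the exchange of two fluorines for one methoxy. On that basis no step beyond the scatter is expected in this assay, with a 1.3-fold higher number from compound 3 to compound 4 (0.10 log units; within the scatter) as the estimated shift. Compound 4 is therefore expected to give 160 nM, within a range of 70 nM to 360 nM.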

Compound 4, half-maximal inhibitory concentration: 200 nM
For compound 4 the middle estimate is 1.3-fold (0.10 log units) below the measured one; the measured number falls inside the stated range.
By their numbers in this assay, from the lowest: compounds 2, 3, 1 and 4 (each within the scatter of the next).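

In this assay, fluoro in place of methoxy on this aromatic carbon, meta to a large group, gives a 1.6-fold higher number from compound 3 to compound 4 (0.20 log units; within the scatter), a direct exchange of these two groups at a single fixed place. Hydrogen in place of one fluoro gives no change at the digits printed from compound 1 to compound 4 (within the scatter), and the 3-fluorophenyl group in place of the 4-methoxyphenyl group gives a 1.6-fold higher number from compound 2 to compound 4 (0.21 log units; within the scatter), so these four substitution patterns on the aromatic ring cannot be told apart on these numbers. Nothing available bears on why these groups read alike.

As far as these compounds go, every step on this ring lies within the scatter, so it remains open whether any substituent here can move the number beyond it. An amine or a carboxylic acid on the same aromatic carbon would put that question to a different kind of group.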